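The compounds below may be only part of what the source reports. "The series", "measured", "known", "first", "only" and "open" are said of these compounds alone.

Working notes on the series: in a functional assay on HCT-116 cells (Homo sapiens) for inhibition, read by CCK-8 assay, with a stated time of 48 h (on this read-out higher numbers stand for weaker inhibition and lower numbers for stronger inhibition), compound 1 (`COc1cc(-c2ccnc3cc(-c4ccccc4)nn23)cc(OC)c1OC`) gives 3880 nM while compound 2 (`COc1cc(-c2ccnc3cc(-c4ccc(C(F)(F)F)cc4)nn23)cc(OC)c1OC`) gives 1860 nM and compound 3 (`COc1ccc(-c2cc3nccc(-c4cc(OC)c(OC)c(OC)c4)n3n2)cc1F`) gives 2840 nM on this read-out. Compound 3 lies within the scatter of both other compounds, with a 1.4-fold lower number from compound 1 to compound 3 (0.14 log units; within the scatter) and a 1.5-fold higher number from compound 2 to compound 3 (0.18 log units; within the scatter) both inside it.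

The next change, 4-(tert-butyl)phenyl in place of 3-fluoro-4-methoxyphenyl on an aromatic carbon leading to compound 4 (`COc1cc(-c2ccnc3cc(-c4ccc(C(C)(C)C)cc4)nn23)cc(OC)c1OC`), puts 4-(tert-butyl)phenyl in place of 3-fluoro-4-methoxyphenyl on an aromatic carbon of the five-membered aromatic ring. Among the compounds with values here, only two measured steps bear on this position directly. The first, a 2.1-fold lower number from compound 1 to compound 2 (0.32 log units; beyond the scatter) for compound 2, is modest and the only one beyond the scatter. The second, a 1.5-fold higher number from compound 2 to compound 3 (0.18 log units; within the scatter) for the exchange of one substituted phenyl for another, stays inside it. Within the data shown here, no direct precedent for 4-(tert-butyl)phenyl exists, so no step beyond the scatter is expected in this assay for this change. The estimated move is a 1.2-fold lower number from compound 3 to compound 4 (0.09 log units; within the scatter) and it is expected to remain small. For compound 4 the estimated value is 2300 nM with an expected range of 1000 nM to 5000 nM in these notes.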

Compound 4, half-maximal inhibitory concentration: > 10000 nM
Compound 4: a limit, no number; the forecaster's own chance of this, stated with the estimate: 3%; middle value at least 4.3-fold (0.63 log units) away from the limit.
By their numbers in this assay, from the lowest: compounds 2, 3 and 1 (each within the scatter of the next, the first and the last beyond it). At a limit, above all of these: compound 4.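

In this assay the reading for compound 4 is a limit and not a number: the limit of > 10000 nM in this assay, at which 1 of the 4 values shown sits. Within the data shown here, the aryl group on this carbon of the five-membered ring had so far produced only small differences, whereas 4-(tert-butyl)phenyl gives steps beyond the scatter against all three earlier compounds, with an at least 3.5-fold higher number from compound 3 to compound 4 (0.54 log units; beyond the scatter), an at least 5.3-fold higher number from compound 2 to compound 4 (0.73 log units; beyond the scatter) and an at least 2.5-fold higher number from compound 1 to compound 4 (0.41 log units; beyond the scatter). The position therefore does not tolerate every substituted phenyl, and the direction depends on the group: trifluoromethyl gives a 2.1-fold lower number from compound 1 to compound 2 (0.32 log units; beyond the scatter), while tert-butyl moves the other way.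

On these data alone, how far compound 4 lies past the limit remains unknown, so the true size of these steps stays open. Also open, as far as these compounds go, is whether a methyl, an isopropyl or a dimethylamino group in place of tert-butyl would read close to compound 2 or would also reach the limit.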